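Notes on a pyrazole series: second trifluoromethyl on urea

The source may report more compounds than this note shows. Statements on the series, on what has been measured and on what is new or still open speak of the compounds shown alone.

Measured so far:
- compound 1 `COc1cc(Cl)cc(-c2nn(-c3cccc(NC(=O)Nc4cccc(C(F)(F)F)c4)c3)cc2-c2ccncc2)c1`: -80% in a functional assay on RXF 393 cells (Homo sapiens) for inhibition, read by sulforhodamine B assay, with a stated time of 48 h, tested at 100 uM; on this read-out lower numbers stand for a stronger effect and higher numbers for a weaker effect at the one concentration tested
- compound 2 `COc1cc(Cl)cc(-c2nn(-c3cccc(NC(=O)c4cccc(C(F)(F)F)c4)c3)cc2-c2ccncc2)c1`: 19% in this assay

Compound 1 gives the lowest of the two numbers; the nearest measured neighbour, compound 2, differs by a number 99 percentage points higher from compound 1 to compound 2 (beyond the scatter), a change at the carbonyl carbon and not on the aryl ring carrying the trifluoromethyl group.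

The unmeasured compound 3 `COc1cc(Cl)cc(-c2nn(-c3cccc(NC(=O)Nc4cc(C(F)(F)F)cc(C(F)(F)F)c4)c3)cc2-c2ccncc2)c1` differs from compound 1 by trifluoromethyl in place of hydrogen on an aromatic carbon. Among the compounds with values here, no measured pair alters a substituent on that ring: the only step in hand, a number 99 percentage points higher from compound 1 to compound 2 (beyond the scatter), concerns the urea-to-amide exchange and says nothing about a second trifluoromethyl group on the aryl ring. Within the data shown here, there is therefore no step that bears directly on the change from compound 1 to compound 3, and the expectation has to rest on compound 1 alone.

With the urea of compound 1 kept intact, the step from compound 1 to compound 3 is expected to be a number 10 percentage points higher from compound 1 to compound 3 (within the scatter), within the scatter. Compound 3 is estimated at -70%, in the range -100% to -10%.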

Compound 3, a percentage reported as activity, at one concentration (the size of the read-out at that concentration, not a potency): -92%
For compound 3 the middle estimate is 22 percentage points above the measured one; low and high end bracket the measured number.
By their numbers in this assay, from the lowest: compound 3; then compound 1; then compound 2.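

Trifluoromethyl in place of hydrogen on an aromatic carbon, meta to a trifluoromethyl group and meta to a large group, gives in this assay a number 12 percentage points lower from compound 1 to compound 3 (beyond the scatter), the first measured change on this aryl ring. The urea-bearing series therefore keeps its strongly negative read-out with this added group of 4 heavy atoms, and the step is modest beside a number 99 percentage points higher from compound 1 to compound 2 (beyond the scatter), so among these three compounds the change at the carbonyl carbon moves the number much further than the change on the ring. No measurement at hand speaks to what lies behind the ring step.

Still open, from the compounds shown here alone, is whether this aromatic carbon would give a similar step with a nitrile or an amine in place of the trifluoromethyl group, and whether a second trifluoromethyl on the amide of compound 2 would shift the number in the same direction. The read-out at one concentration also leaves open how compound 1 and compound 3 would compare across a range of concentrations.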